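The compounds below may be only part of what the source reports. "The series", "measured", "known", "first", "only" and "open" are said of these compounds alone.

Of the compounds shown here, three of a shared core have been measured in a physicochemical assay for lipophilicity, in phosphate buffer, measured as octanol-water partition, with a stated time of 24 h; on this read-out lower numbers stand for lower lipophilicity and higher numbers for higher lipophilicity. Compound 1 `O=[N+]([O-])c1ccc(Oc2ccc(/C=N/NC(=S)Nc3ccc(Cl)cc3)cc2)cc1` gives 5.52 in this assay. Compound 2 `S=C(N/N=C/c1ccc(Oc2ccc(Cl)cc2)cc1)Nc1ccc(Cl)cc1` differs from compound 1 in one place, (chloro in place of nitro on an aromatic carbon), and in this assay compound 2 gives 6.2. The step is a number 0.68 log units higher from compound 1 to compound 2 (beyond the scatter). Compound 3 `O=[N+]([O-])c1ccc(Oc2ccc(/C=N/NC(=S)Nc3ccc(F)cc3)cc2)cc1` differs from compound 1 in another place, (fluoro in place of chloro on an aromatic carbon), and in this assay compound 3 gives 4.89, a step of a number 0.63 log units lower from compound 1 to compound 3 (beyond the scatter).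

Compound 4 `Fc1ccc(NC(=S)N/N=C/c2ccc(Oc3ccc(Cl)cc3)cc2)cc1` has not yet been measured. It differs from compound 3 by chloro in place of nitro on an aromatic carbon, the same change already made from compound 1 to compound 2, at a place described in the same words. The cores of compound 3 and compound 1 differ as told by fluoro in place of chloro on an aromatic carbon. On that basis compound 4 is expected to show a number 0.68 log units higher from compound 3 to compound 4 (beyond the scatter), because the earlier step of the same kind was a number 0.68 log units higher from compound 1 to compound 2 (beyond the scatter). For compound 4 the expected value in this assay is 5.57, with a range from 5.2 to 5.95.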

Compound 4, partition coefficient: 5.78
Estimate against measurement, compound 4: 0.21 log units below, within the range that was stated.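

In this assay chloro in place of nitro gives a number 0.68 log units higher from compound 1 to compound 2 (beyond the scatter) and a number 0.89 log units higher from compound 3 to compound 4 (beyond the scatter) on the second core, so the change keeps its direction when carried from the core of compound 1 to the core of compound 3. Fluoro in place of chloro also keeps its direction, with a number 0.63 log units lower from compound 1 to compound 3 (beyond the scatter) and a number 0.42 log units lower from compound 2 to compound 4 (beyond the scatter) when the same change is made on the pair that carries chloro instead of nitro. Within the data shown here, these are only two cores, so no rule for the wider series follows, and nothing measured here says what lies behind the size of any of these steps.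

Only nitro and chloro appear at the one changing place, and only chloro and fluoro at the other. On these data alone, whether other groups, such as an amine or a carboxylic acid in place of nitro, would shift the number in the same way on both cores remains open.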